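Swapping one ring group on a growth-inhibiting amine

The compounds below may be only part of what the source reports. "The series", "measured", "known", "first", "only" and "open" are said of these compounds alone.

Compound 1 `Cc1cc(CNCc2ccccc2)c(C)n1-c1ccc(Cl)cc1`: 7.2 ug/mL
Compound 2 `Cc1cc(CN2CCN(C3C[C@@H]4CC[C@H]3C4)CC2)c(C)n1-c1ccc(Cl)cc1`: 16 ug/mL
Compound 3 `Cc1c(CN2CCN(C3CC4CCC3C4)CC2)cc(-c2ccc(Cl)cc2)n1-c1ccc(Cl)cc1`: 429 ug/mL

For the measured compounds named here, only three compounds have been measured so far, and no two of them differ in just one place. In an ADME assay on THP-1 cells (Homo sapiens) for cytotoxicity, read by trypan blue exclusion, with a stated time of 48 h (a lower number here means a stronger inhibitor of growth, a higher number a weaker inhibitor of growth), compound 2 gives 16 ug/mL, the second highest of the three numbers. Compound 1 lies lower with 7.2 ug/mL, and compound 3 lies much higher with 429 ug/mL. Both gaps from compound 2 are beyond the scatter.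

The next compound to be tested is compound 4 `Cc1cc(CN2CCN(c3ccccc3)CC2)c(C)n1-c1ccc(Cl)cc1`. It keeps the core of compound 2 and changes one group: a group of 6 heavy atoms (6 carbon; one six-membered aromatic ring of carbon only) in place of a group of 7 heavy atoms (7 carbon; 2 five-membered non-aromatic rings of carbon only), on an amine nitrogen in a ring. The new phenyl sits on the same amine nitrogen in a ring.

Going by the values given here, the data contain no measured example of this swap, so any forecast is uncertain. Among the compounds with values here, the closest guide is compound 2 with 16 ug/mL, since only this one group separates it from compound 4. Compound 3 is a poorer guide, as its core differs as well. In this assay the expected change is small and within the scatter, with no clear direction: the estimated step is a 1.1-fold lower number from compound 2 to compound 4 (0.06 log units; within the scatter). For compound 4 the estimated value is 14 ug/mL, with an expected range of 5 ug/mL to 45 ug/mL.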

Compound 4, concentration for 50% growth inhibition: 25 ug/mL
For compound 4 the middle estimate is 1.8-fold (0.25 log units) below the measured one, and the stated range covers the measured number.
By their numbers in this assay, from the lowest: compound 1; then compounds 2 and 4 (each within the scatter of the next); then compound 3.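

In this assay, for the compounds shown here, putting phenyl on the amine nitrogen in place of the group with two five-membered non-aromatic rings gives a 1.6-fold higher number from compound 2 to compound 4 (0.19 log units; within the scatter), the first comparison here in which only one group differs. At this position, then, a six-membered aromatic carbon ring and a two-ring non-aromatic carbon group cannot be told apart in this test, even though the group that leaves has 2 defined stereocentres and phenyl has none. No measurement here explains this result, and nothing shows which feature of either group matters, if any does.

On these data alone, both groups in this comparison contain only carbon and have no hydrogen-bond donors or acceptors, so it remains open whether a pyridine ring, a carboxylic acid or a hydroxyethyl chain on the same nitrogen would give a similar number. As far as these compounds go, it also remains open whether phenyl would give a similar result on the different core of compound 3, which carries an extra 4-chlorophenyl group and has a much higher number than compound 2.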